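Benzyl Substituent Swap on an Indazole Ester Series

The source may hold more compounds than are shown below. What is called first, only, known or untested is meant among the compounds shown, and "the series" means these compounds.

Measured so far:
Compound 1, `CCOC(=O)c1ccc(-c2nn(Cc3ccc(Cl)cc3)c3ccccc23)cc1`: > 10000 nM
Compound 2, `CCOC(=O)c1ccc(-c2nn(Cc3ccc(F)cc3)c3ccccc23)cc1`: > 10000 nM

In a functional assay on cells (Platelet, Homo sapiens) for inhibition (on this read-out lower numbers stand for stronger inhibition and higher numbers for weaker inhibition), compound 1 gives > 10000 nM, which is a limit of the assay and not a number. In this assay compound 2 likewise gives > 10000 nM, again a limit rather than a measured number. The step from compound 1 to compound 2 is therefore a step that the two limits leave unreadable from compound 1 to compound 2, and the two values share (the limit of > 10000 nM in this assay, at which 2 of the 2 values shown sit).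

Compound 3, `CCOC(=O)c1ccc(-c2nn(Cc3ccccc3OC)c3ccccc23)cc1`, has not yet been measured. It differs from compound 2 by 2-methoxyphenyl in place of 4-fluorophenyl on a saturated chain carbon bound to an aromatic nitrogen.

Among the measured compounds shown here, only one measured step exists, and it is unreadable, so it gives no direction for the change to compound 3. Both measured compounds sit at the same limit, and the benzyl change to compound 3 is a modest one on the same shared core. Compound 3 is therefore expected to stay near that limit, with a step that the limit leaves unreadable from compound 2 to compound 3 as the estimated step. The estimate for compound 3 in this assay is 15000 nM, with a range from 4000 nM to 60000 nM, and most likely only a limit will again be reported.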

Compound 3, half-maximal inhibitory concentration: > 10000 nM
Compound 3: no number, only a limit; the forecaster's own chance of this, stated with the estimate: 80%; the middle value is on the limit's open side.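

In this assay compound 3 gives > 10000 nM, which is a limit of the assay and not a number. Among the compounds shown here, no step among compound 1, compound 2 and compound 3 can be read, as all three sit at one shared limit: the limit of > 10000 nM in this assay, at which 3 of the 3 values shown sit. The compounds shown leave open how strongly each inhibits, and whether changing the benzyl group makes any difference.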